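A few compounds are considered here, and "the series" means these few. Any claim that something is new, unique, unknown or untested is made for them only; others in the source may bear on it.

Working notes on the series. Among the measured compounds shown here, in a functional assay on HUVEC cells (Homo sapiens), read by scintillation counting and thymidine incorporation, with a stated time of 24 h (on this read-out lower numbers stand for stronger inhibition and higher numbers for weaker inhibition), compound 1 `CCC(C)n1ncn(-c2ccc(N3CCN(c4ccc(OC[C@@H]5CO[C@@](Cc6ccccc6)(c6ccc(Cl)cc6Cl)O5)cc4)CC3)cc2)c1=O` gives 513 nM and compound 2 `CCC(C)n1ncn(-c2ccc(N3CCN(c4ccc(OC[C@@H]5CO[C@@](Cn6cnc(C)c6)(c6ccc(Cl)cc6Cl)O5)cc4)CC3)cc2)c1=O` gives 102 nM, so compound 2 holds the lower of the two numbers so far. Compound 3 `CCC(C)n1ncn(-c2ccc(N3CCN(c4ccc(OC[C@@H]5CO[C@@](Cn6nnnc6-c6ccccc6)(c6ccc(Cl)cc6Cl)O5)cc4)CC3)cc2)c1=O` carries 5-phenyl-1H-tetrazol-1-yl in place of 4-methyl-1H-imidazol-1-yl on a saturated chain carbon bound to a saturated ring carbon. For the measured compounds named here, only one measured step bears on this change. It is a 5.0-fold lower number from compound 1 to compound 2 (0.70 log units; beyond the scatter), a modest step beyond the scatter, made at the same place with 4-methyl-1H-imidazol-1-yl in place of phenyl. The entering group holds a five-membered aromatic ring with hetero atoms, as compound 2 does, together with a six-membered aromatic ring of carbon only, so compound 3 is not clearly tied to either measured compound. Going by the values given here, a single step fixes no pattern, and no measured compound carries a tetrazolyl group. Among the compounds with values here, a modest rise toward weaker inhibition is expected, of no greater size than the one measured step. The expected step is a 2.2-fold higher number from compound 2 to compound 3 (0.33 log units; beyond the scatter), and its direction remains uncertain. For compound 3 the estimated value is 220 nM, with an expected range of 70 nM to 700 nM.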

Compound 3, half-maximal inhibitory concentration: 119 nM
Estimate against measurement, compound 3: 1.8-fold (0.27 log units) above; low and high end bracket the measured number.
By their numbers in this assay, from the lowest: compounds 2 and 3 (each within the scatter of the next); then compound 1.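

In this assay the change from 4-methyl-1H-imidazol-1-yl to 5-phenyl-1H-tetrazol-1-yl gives a 1.2-fold higher number from compound 2 to compound 3 (0.07 log units; within the scatter) and so leaves the number within the scatter, even though the entering group has 11 heavy atoms against 6 and adds a six-membered aromatic ring of carbon only. On a saturated chain carbon bound to a saturated ring carbon, a second group with a five-membered aromatic ring bearing hetero atoms now stands apart from the phenyl of compound 1, with a 4.3-fold lower number from compound 1 to compound 3 (0.63 log units; beyond the scatter) beyond the scatter, so this separation no longer rests on compound 2 alone. Nothing measured on these compounds accounts for either result.

The compounds shown leave open whether the phenyl on the tetrazole contributes anything, since an unsubstituted 1H-tetrazol-1-yl group would be needed to separate it from the five-membered ring. They also leave open how an open-chain dimethylamino group, a carboxylic acid or a saturated morpholine ring would behave on the same chain carbon, and so whether an aromatic ring with hetero atoms is needed there at all.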